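Side-chain swap on a shared core: expected potency

The source may report more compounds than this note shows. Statements on the series, on what has been measured and on what is new or still open speak of the compounds shown alone.

Compound 1 `C[C@H](NC(=O)c1cc2ccccc2cn1)C(=O)OCc1ccccc1`, compound 2 `NC(=O)CC[C@H](NC(=O)c1cc2ccccc2cn1)C(=O)OCc1ccccc1` and compound 3 `NCCCC[C@H](NC(=O)c1cc2ccccc2cn1)C(=O)OCc1ccccc1` share one core and differ only in the side chain. In a functional assay on HL-60 cells (Homo sapiens) for antiproliferative activity, read by MTT assay, with a stated time of 48 h (on this read-out higher numbers stand for weaker inhibition and lower numbers for stronger inhibition), compound 1 gives 84.8 nM, compound 2 gives 44.5 nM and compound 3 gives 68.2 nM. Compound 3 therefore stands second highest of the three numbers, nearest to compound 1 and furthest from compound 2, yet every gap stays within the scatter. Compound 4 `O=C(CC[C@H](NC(=O)c1cc2ccccc2cn1)C(=O)OCc1ccccc1)OCc1ccccc1` carries benzyloxycarbonyl in place of 2-aminoethyl on a saturated chain carbon, three bonds along the chain from an amide-type nitrogen and a carbonyl carbon. The side-chain steps measured so far, a 1.2-fold lower number from compound 1 to compound 3 (0.09 log units; within the scatter) and a 1.5-fold higher number from compound 2 to compound 3 (0.19 log units; within the scatter), were both within the scatter, and none of them brought in a benzyloxycarbonyl group, so the expected step is a 1.1-fold lower number from compound 3 to compound 4 (0.06 log units; within the scatter), nothing beyond the scatter. Compound 4 is estimated at 60 nM in this assay, with a range from 20 nM to 180 nM.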

Compound 4, half-maximal inhibitory concentration: 83.6 nM
For compound 4 the middle estimate is 1.4-fold (0.14 log units) below the measured one, within the range that was stated.
By their numbers in this assay, from the lowest: compounds 2, 3, 4 and 1 (each within the scatter of the next).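

In this assay this position takes a much larger side chain bearing an aromatic ring and no hydrogen-bond donor: benzyloxycarbonyl in place of 2-aminoethyl gives a 1.2-fold higher number from compound 3 to compound 4 (0.09 log units; within the scatter) and still lies within the scatter. Benzyloxy in place of amino on a carbonyl carbon gives a 1.9-fold higher number from compound 2 to compound 4 (0.27 log units; within the scatter) and (benzyloxycarbonyl)methyl in place of hydrogen gives a 1.0-fold lower number from compound 1 to compound 4 (0.01 log units; within the scatter) and both also lie within the scatter. No available measurement explains this tolerance. Still open, from the compounds shown here alone, is whether a free carboxylic acid or a longer chain here would move the number beyond the scatter.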